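This account rests on a few compounds, and the source may have more. Where it says the series, first, only, none or still open, it means among the compounds named here.

Of the compounds shown here, two from this set have been tested in a functional assay on KBVIN cells (Homo sapiens) for antiproliferative activity, read by sulforhodamine B assay, with a stated time of 3 days; on this read-out lower numbers stand for an effect already at smaller amounts and higher numbers for an effect only at larger amounts of compound. Compound 1 `CCC1=C(O)c2c(oc(-c3ccc(OC)cc3)cc2=O)C(CC)(CC)C1=O` gives 0.68 uM, and compound 2 `CCC1=C(O)c2c(oc(-c3cccc(C(F)(F)F)c3)cc2=O)C(CC)(CC)C1=O` gives 5.42 uM. Of the two numbers, compound 1 has the lowest; the number of compound 2 lies above it by more than the usual scatter, so compound 1 is the more active of the pair. Compound 3 `CCC1=C(O)c2c(oc(-c3ccccc3OC)cc2=O)C(CC)(CC)C1=O` has not yet been measured. It shares every atom with compound 1, but the atoms are joined differently: 2-methoxyphenyl in place of 4-methoxyphenyl on an aromatic carbon. The methoxy group thus stays on the phenyl ring, while the shared core is untouched. Among the compounds with values here, no measured pair in this set shows what such a move of the methoxy group does, so the expectation rests on the single number of compound 1 and on caution. A modest weakening is expected, with a step of a 2.6-fold higher number from compound 1 to compound 3 (0.42 log units; beyond the scatter) that would still leave compound 3 closer to compound 1 than to compound 2. Compound 3 is therefore estimated at 1.8 uM, within a range from 0.6 uM to 5 uM.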

Compound 3, concentration for half-maximal effect: 3.26 uM
Estimate against measurement, compound 3: 1.8-fold (0.26 log units) below; measured number inside the range.
By their numbers in this assay, from the lowest: compound 1; then compounds 3 and 2 (each within the scatter of the next).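

Within the data shown here, compound 1 and compound 3 hold the same atoms, so the only change is where the methoxy group sits on the phenyl ring, and in this assay this gives a 4.8-fold higher number from compound 1 to compound 3 (0.68 log units; beyond the scatter). The step lies beyond the usual scatter, which shows that the placement of the methoxy group matters on its own, with no atom gained or lost: of the two placements, 4-methoxyphenyl gives the lower number, and with 2-methoxyphenyl the value of compound 3 comes within the scatter of the value of compound 2. Nothing available here explains why moving the group has this effect.

As far as these compounds go, it remains open whether a longer chain such as ethoxy in place of methoxy, or an amine or a carboxylic acid on the phenyl ring, would keep the activity of compound 1 in this assay. Among these compounds, it is also open whether the same move of the methoxy group would give a step of similar size on a different core, as this one pair is the only direct evidence for it.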